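The source may report more compounds than this note shows. Statements on the series, on what has been measured and on what is new or still open speak of the compounds shown alone.

Compound 3 `C=CCc1cc(-c2ccc(O)c(CC=C)c2)c(O)c(C(c2ccc(Cl)cc2)N2CCCC2)c1` carries pyrrolidin-1-yl on a saturated chain carbon bound to two aromatic carbons. In an assay on isolated protein for inhibition of Maltase-glucoamylase (Homo sapiens), with stated times of 15 min and 10 min, tested at 64 uM (on this read-out higher numbers stand for more inhibition at the one concentration tested (going by the name of the read-out) and lower numbers for less inhibition), compound 3 gives 40.6%, the second highest of the three numbers in hand. Going by the values given here, compound 1 `C=CCc1cc(-c2ccc(O)c(CC=C)c2)c(O)c(C(c2ccc(OC)cc2)N2CCCCC2)c1` gives 85% in this assay, and compound 2 `C=CCc1cc(-c2ccc(O)c(CC=C)c2)c(O)c(C(c2ccccc2)N2CCCCC2)c1` gives 13.6%; the one step measured, a number 71.4 percentage points lower from compound 1 to compound 2 (beyond the scatter), replaces methoxy with hydrogen on an aromatic carbon, a change on the aromatic part and not on the amine ring.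

Compound 4 `C=CCc1cc(-c2ccc(O)c(CC=C)c2)c(O)c(C(c2ccc(Cl)cc2)N2CCCCC2)c1` differs from compound 3 in one place: piperidin-1-yl in place of pyrrolidin-1-yl on a saturated chain carbon bound to two aromatic carbons. Among the compounds with values here, no measured pair covers this ring change on its own, so the step from compound 1 to compound 2 does not bear on it directly; it shows only that the read-out in this assay can move strongly with a single change elsewhere in the molecule. Compound 1 and compound 2 both carry piperidin-1-yl and sit far apart, so that ring alone fixes neither a high nor a low number. Within the data shown here, with no direct precedent, no step beyond the scatter is expected for a number 7.4 percentage points higher from compound 3 to compound 4 (within the scatter), though the range is kept wide. Compound 4 is estimated at 48%, expected to fall between 20% and 78%.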

Compound 4, a percentage reported as inhibition, at one concentration (the size of the read-out at that concentration, not a potency): 45%
Compound 4: the middle estimate sits 3 percentage points above what was measured; the measured number falls inside the stated range.
By their numbers in this assay, from the lowest: compound 2; then compounds 3 and 4 (each within the scatter of the next); then compound 1.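

In this assay, the step of a number 4.4 percentage points higher from compound 3 to compound 4 (within the scatter) shows that, with chloro on the aromatic carbon, exchanging pyrrolidin-1-yl for piperidin-1-yl on a saturated chain carbon bound to two aromatic carbons does not separate the two compounds on this read-out. With piperidin-1-yl held fixed, the aromatic carbon now has three measured substituents: chloro in place of hydrogen gives a number 31.4 percentage points higher from compound 2 to compound 4 (beyond the scatter) and chloro in place of methoxy gives a number 40 percentage points lower from compound 1 to compound 4 (beyond the scatter), so the order from the lowest number is hydrogen, chloro, methoxy, with each step beyond the scatter. No measurement available here explains either the small ring step or the wide spread among the aromatic substituents.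

Going by these compounds, whether the ring change stays this small with methoxy or hydrogen on the aromatic carbon remains open, as pyrrolidin-1-yl appears here only together with chloro. Also open, on these data alone, is how morpholin-4-yl or dimethylamino on the saturated chain carbon, or fluoro or ethoxy on the aromatic carbon, would read in this assay.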